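A few compounds are considered here, and "the series" means these few. Any claim that something is new, unique, unknown or untested is made for them only; others in the source may bear on it.

Measured compounds in an ADME assay on a cell-free system (plasma, Homo sapiens) for metabolic stability, read by LC-MS; on this read-out higher numbers stand for a longer-lived compound and lower numbers for a shorter-lived compound:

compound 1, `CCCCOC(=O)c1cccc(-c2cc(C(=O)Nc3ccncc3)ccc2CN)c1`, 0.367 h
compound 2, `CCOC(=O)c1cccc(-c2cc(C(=O)Nc3ccncc3)ccc2CN)c1`, 0.683 h
compound 3, `CCCOC(=O)c1cccc(-c2cc(C(=O)Nc3ccncc3)ccc2CN)c1`, 0.3 h

The three compounds share one core and differ only in the ester chain. Between compound 1 and compound 2 the difference is hydrogen in place of ethyl on a saturated chain carbon, two bonds along the chain from an oxygen next to a carbonyl group, and on this assay it gave a 1.9-fold higher number from compound 1 to compound 2 (0.27 log units; within the scatter). Between compound 1 and compound 3 the difference is hydrogen in place of methyl on a saturated chain carbon, three bonds along the chain from an oxygen next to a carbonyl group, with a 1.2-fold lower number from compound 1 to compound 3 (0.09 log units; within the scatter). Between compound 2 and compound 3 the difference is a methyl in place of hydrogen on a saturated chain carbon, two bonds along the chain from an oxygen next to a carbonyl group, and here the step is a 2.3-fold lower number from compound 2 to compound 3 (0.36 log units; beyond the scatter).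

Compound 4, `COC(=O)c1cccc(-c2cc(C(=O)Nc3ccncc3)ccc2CN)c1`, has not yet been run on this assay. It differs from compound 3 by hydrogen in place of ethyl on a saturated chain carbon bound to an oxygen next to a carbonyl group. Among the compounds with values here, this is the same kind of change as the one from compound 1 to compound 2, but not the same: there the place was a saturated chain carbon two bonds along the chain from an oxygen next to a carbonyl group, whereas here it is a saturated chain carbon bound to an oxygen next to a carbonyl group. The cores of the two pairs differ as given above by hydrogen in place of methyl on a saturated chain carbon, three bonds along the chain from an oxygen next to a carbonyl group.

Within the data shown here, with only one earlier instance of this kind of change, and that one within the scatter, the expectation for compound 4 rests on compound 3 giving 0.3 h and on the earlier step being a 1.9-fold higher number from compound 1 to compound 2 (0.27 log units; within the scatter). The step from compound 3 to compound 4 is expected to be a 1.5-fold higher number from compound 3 to compound 4 (0.18 log units; within the scatter). Compound 4 is thus estimated at 0.45 h, between 0.2 h and 1 h.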

Compound 4, half-life: 1.52 h
The estimate for compound 4 lay 3.4-fold (0.53 log units) below the measured number; measured number above the stated range.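

Hydrogen in place of ethyl does not carry over at one size from core to core in this assay: the same change on two cores in this assay, a 1.9-fold higher number (0.27 log units; within the scatter) from compound 1 to compound 2 and a 5.1-fold higher number (0.70 log units; beyond the scatter) from compound 3 to compound 4, 2.7-fold (0.43 log units) apart, beyond the scatter of two such steps. Hydrogen in place of methyl likewise differs between its two cores: the same change on two cores in this assay, a 1.2-fold lower number (0.09 log units; within the scatter) from compound 1 to compound 3 and a 2.2-fold higher number (0.35 log units; beyond the scatter) from compound 2 to compound 4, 2.7-fold (0.43 log units) apart, beyond the scatter of two such steps. The methoxycarbonyl ester holds the highest number of the four, with a 5.1-fold higher number from compound 3 to compound 4 (0.70 log units; beyond the scatter), a 2.2-fold higher number from compound 2 to compound 4 (0.35 log units; beyond the scatter) and a 4.1-fold higher number from compound 1 to compound 4 (0.62 log units; beyond the scatter), but this rests on a single compound and on two pairs of steps, so it shows that a step taken from one ester chain is a poor guide to the same step on another, and it does not show why the steps differ or whether any rule would hold beyond these four esters.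

Open, going by these compounds, is whether the high number belongs to methoxycarbonyl alone, or whether a branched chain such as isopropoxycarbonyl, a carboxylic acid or an amide in place of the ester would stand near it or near the longer chains. Also open, on these data alone, is whether the same steps along the ester chain would keep their sizes on a core changed elsewhere, since all four compounds share everything outside that chain.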